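Amide aryl swap in the quinoline amide series

The source may report more compounds than this note shows. Statements on the series, on what has been measured and on what is new or still open speak of the compounds shown alone.

Three members of the series carry a number in a functional assay on MCF7 cells (Homo sapiens) for antiproliferative activity, read by MTT assay, with a stated time of 72 h; on this read-out lower numbers stand for stronger inhibition and higher numbers for weaker inhibition. Compound 1 `CCc1ccc(C(=O)Nc2ccc3nc(N4CCN(CC)CC4)cc(C)c3c2)cc1` gives 3060 nM. Compound 2 `CCN1CCN(c2cc(C)c3cc(NC(=O)c4cccc(F)c4)ccc3n2)CC1` gives 8920 nM. Compound 3 `Cc1cc(N2CCCCC2)nc2ccc(NC(=O)c3ccc(Cl)c(Cl)c3)cc12` gives 31100 nM. On these three numbers compound 2 stands second highest: nearest to it is compound 1, furthest from it is compound 3, and both gaps are beyond the scatter. Going by the values given here, the only single-point step among the measured compounds is a 2.9-fold higher number from compound 1 to compound 2 (0.46 log units; beyond the scatter), which is modest.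

Compound 4 `CCN1CCN(c2cc(C)c3cc(NC(=O)c4ccccc4Cl)ccc3n2)CC1` differs from compound 2 in one place: 2-chlorophenyl in place of 3-fluorophenyl on a carbonyl carbon. This is the same position that moved in the step from compound 1 to compound 2, and that step, though beyond the scatter, was small. Compound 3 changes the same aryl group but also the amine on the core, so its value cannot be read as a step. With one halogen-substituted phenyl replacing another of equal atom count, no step beyond the scatter is expected in this assay; compound 4 is therefore expected to sit close to compound 2, with the step of a 1.0-fold higher number from compound 2 to compound 4 (0.00 log units; within the scatter) treated as essentially flat. The estimate for compound 4 in this assay is 9000 nM, with a range from 3000 nM to 27000 nM.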

Compound 4, half-maximal inhibitory concentration: > 50000 nM
Compound 4: only a limit was reported; the forecaster's own chance of this, stated with the estimate: 5%; middle value at least 5.5-fold (0.74 log units) from the limit.
By their numbers in this assay, from the lowest: compound 1; then compound 2; then compound 3. At a limit, above all of these: compound 4.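

Compound 4 reaches only a limit in this assay, not a number: the limit of > 50000 nM in this assay, at which 1 of the 4 values shown sits.

The aryl group on the carbonyl carbon proves far less tolerant than the first step suggested: a 2.9-fold higher number from compound 1 to compound 2 (0.46 log units; beyond the scatter) was modest, whereas an at least 5.6-fold higher number from compound 2 to compound 4 (0.74 log units; beyond the scatter) and an at least 16-fold higher number from compound 1 to compound 4 (1.21 log units; beyond the scatter) are both much wider, the last of them large. Replacing 3-fluorophenyl with 2-chlorophenyl leaves the heavy atom count and the hydrogen-bond donor and acceptor counts unchanged, so equal counts at this position do not mean equal read-outs in this series, and both new steps are lower bounds whose true size stays unread.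

This change alters the halogen and its place on the ring together, and 2-fluorophenyl and 3-chlorophenyl would be needed to tell the two apart. Also open, from the compounds shown here alone, is whether a phenyl carrying an amine or a methoxy group, or a cyclohexyl group, on the same carbonyl carbon would read on the side of compound 1 or of compound 4, and whether the 2-chlorophenyl result carries over to the amine on the core of compound 3.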